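Furan for Benzofuran on a Nucleoside Core: Cell Viability

The compounds below may be only part of what the source reports. "The series", "measured", "known", "first", "only" and "open" are said of these compounds alone.

The study compares four nucleoside analogues in an ADME assay on MRC5 cells (Homo sapiens), read by MTT assay, with a stated time of 72 h; a higher number here means a weaker inhibitor, a lower number a stronger inhibitor. Compound 1 `Nc1nc2c(c(-c3ccco3)cn2[C@@H]2O[C@H](CO)[C@@H](O)[C@H]2O)c(=O)[nH]1` reaches only a limit of the measurement, > 100000 nM. Compound 2 `Nc1nc2c(c(-c3cc4ccccc4o3)cn2[C@@H]2O[C@H](CO)[C@@H](O)[C@H]2O)c(=O)[nH]1` likewise sits at a limit, > 100000 nM. Compound 3 `CNc1ncnc2c1c(-c1cc3ccccc3o1)cn2[C@@H]1O[C@H](CO)[C@@H](O)[C@H]1O` gives 75300 nM. How the core of compound 3 differs from the core of compound 2 is not broken down here. The change from compound 2 to compound 1 furan-2-yl in place of 1-benzofuran-2-yl on an aromatic carbon produced a step that the two limits leave unreadable from compound 2 to compound 1, which cannot be read because of the limit of > 100000 nM in this assay, at which 2 of the 3 values shown sit. Compound 4 `CNc1ncnc2c1c(-c1ccco1)cn2[C@@H]1O[C@H](CO)[C@@H](O)[C@H]1O` carries the same change on the core of compound 3 (furan-2-yl in place of 1-benzofuran-2-yl on an aromatic carbon). The step from compound 3 to compound 4 is accordingly expected to be a 1.3-fold higher number from compound 3 to compound 4 (0.12 log units; within the scatter). This expectation rests on compound 3 giving 75300 nM, and on the measured step being unreadable. Compound 4 is therefore expected to give 100000 nM, between 50000 nM and 200000 nM, and may well be reported only as a limit.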

Compound 4, half-maximal inhibitory concentration: 90800 nM
Compound 4: the middle estimate sits 1.1-fold (0.04 log units) above what was measured; the measured number falls inside the stated range.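

On the core of compound 3, furan-2-yl in place of 1-benzofuran-2-yl gives a 1.2-fold higher number from compound 3 to compound 4 (0.08 log units; within the scatter) in this assay. The same change on the core of compound 2 cannot be read, because compound 2 and compound 1 both stand at a limit of the measurement: the limit of > 100000 nM in this assay, at which 2 of the 4 values shown sit. The result therefore shows one readable step on one core, and it does not show that the change behaves alike on both cores.

The compounds shown leave open whether a different group on this aromatic carbon, such as an amine or a carboxylic acid, would give a step beyond the scatter in this assay. They also leave open how the change would read on any further core.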